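The source may report more compounds than this note shows. Statements on the series, on what has been measured and on what is new or still open speak of the compounds shown alone.

Measured compounds in a physicochemical assay for solubility, read by HPLC, in phosphate buffer, with a stated time of 24 h, at pH 6.8; a higher number here means a more soluble compound, a lower number a less soluble compound:
compound 1, `CC(C)(C)OC(=O)N1CCC2(CC1)CC(CCCOc1ccc(S(C)(=O)=O)cc1)C2`, < 0.13 ug/mL
compound 2, `CC(C)OC(=O)N1CCC2(CC1)CC(CCCOc1ccc(S(C)(=O)=O)cc1)C2`, 0.17 ug/mL
compound 3, `CCc1cnc(N2CCC3(CC2)CC(CCCOc2ccc(S(C)(=O)=O)cc2)C3)nc1`, < 0.12 ug/mL

Compound 3 stands at the floor: its reading is a limit of this assay, not a number (the limit of < 0.12 ug/mL in this assay, at which 1 of the 3 values shown sits). The reading of compound 1 is likewise a limit (the limit of < 0.13 ug/mL in this assay, at which 1 of the 3 values shown sits). Compound 2 alone gives a number, and the steps of an at least 1.3-fold higher number from compound 1 to compound 2 (0.11 log units; that floor lies within the scatter) and an at least 1.4-fold lower number from compound 2 to compound 3 (0.15 log units; that floor lies within the scatter) carry only floors that sit within the scatter, while a step that the two limits leave unreadable from compound 1 to compound 3 cannot be read at all.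

Compound 4, `CC(C)c1noc(N2CCC3(CC2)CC(CCCOc2ccc(S(C)(=O)=O)cc2)C3)n1`, differs from compound 3 by 3-isopropyl-1,2,4-oxadiazol-5-yl in place of 5-ethylpyrimidin-2-yl on an amine nitrogen in a ring. Among the compounds with values here, no measured step swaps one aromatic ring on that nitrogen for another; the two steps that reach compound 3 exchange tert-butoxycarbonyl or isopropoxycarbonyl for 5-ethylpyrimidin-2-yl and end at the floor. They give no ground for a move beyond the scatter in this assay in either direction, and the readout may again be a limit. Compound 4 is therefore expected to remain near the floor, an at least 1.2-fold higher number from compound 3 to compound 4 (0.09 log units; that floor lies within the scatter). The estimate for compound 4 is 0.15 ug/mL, with a range of 0.05 ug/mL to 0.6 ug/mL.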

Compound 4, solubility: < 0.13 ug/mL
Compound 4: no number, only a limit; the forecaster's own chance of this, stated with the estimate: 55%; at least 1.1-fold (0.06 log units) between middle value and limit.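

In this assay compound 4 reads as a limit and not a number: the limit of < 0.13 ug/mL in this assay, at which 2 of the 4 values shown sit.

With 3-isopropyl-1,2,4-oxadiazol-5-yl in place of 5-ethylpyrimidin-2-yl, a second aromatic ring on this amine nitrogen gives no number, and the steps to compound 4 from compound 3 and from compound 1 cannot be read, as both ends of each are limits. Within the data shown here, the one readable step is an at least 1.3-fold lower number from compound 2 to compound 4 (0.11 log units; that floor lies within the scatter), and compound 2 remains the only compound with a number.

As far as these compounds go, whether the two aromatic rings differ at all in this assay stays open, as any gap between them lies hidden under the limits. Also open, from the compounds shown here alone, is whether a group of another kind on this nitrogen, such as a carboxylic acid or an amine, would give a number in this assay.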